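Hydroxy to methoxy on the chlorophenyl arm of compound 1

The source may hold more compounds than are shown below. What is called first, only, known or untested is meant among the compounds shown, and "the series" means these compounds.

Two compounds of the series have numbers in a functional assay on UO-31 cells (Homo sapiens) for inhibition, read by sulforhodamine B assay, with a stated time of 48 h; on this read-out higher numbers stand for weaker inhibition of growth and lower numbers for stronger inhibition of growth. Compound 1 `O=C(Nc1cccc(-n2cc(-c3ccncc3)c(-c3ccc(Cl)c(O)c3)n2)c1)Nc1cc(C(F)(F)F)cc(C(F)(F)F)c1` gives 1900 nM, the lower of the two. Compound 2 `COc1cc(-c2nn(-c3cccc(NC(=O)Nc4ccc(Cl)c(Cl)c4)c3)cc2-c2ccncc2)ccc1Cl`, which carries a methoxy group and a different aryl group on the urea, gives 4980 nM; the gap between these two values lies beyond the scatter, but the structures differ in more than one place, so the methoxy group alone cannot be held to account for it.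

Compound 3 `COc1cc(-c2nn(-c3cccc(NC(=O)Nc4cc(C(F)(F)F)cc(C(F)(F)F)c4)c3)cc2-c2ccncc2)ccc1Cl` has not been measured. It differs from compound 1 in a single place: methyl in place of hydrogen on an oxygen on an aromatic ring.

For the measured compounds named here, no single-change step between measured compounds is available. The change is expected to be small, perhaps not beyond the scatter, with the higher number of compound 2 at 4980 nM the only hint, pointing, if anywhere, toward a slightly higher number. The step is expected to be a 1.4-fold higher number from compound 1 to compound 3 (0.14 log units; within the scatter). Compound 3 is estimated at 2600 nM, within a range from 1100 nM to 6500 nM.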

Compound 3, concentration for total growth inhibition: 1280 nM
The estimate for compound 3 lay 2.0-fold (0.31 log units) above the measured number; the range from low to high includes it.
By their numbers in this assay, from the lowest: compounds 3 and 1 (each within the scatter of the next); then compound 2.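

In this assay the change from hydroxy to methoxy on the chlorophenyl arm is a 1.5-fold lower number from compound 1 to compound 3 (0.17 log units; within the scatter) and so cannot be told apart from repeat scatter. With the urea aryl group of compound 1 in place, this oxygen therefore accepts a methyl in place of its hydrogen, and that hydrogen is not needed to hold the level of growth inhibition. Compound 3 gives 1280 nM while compound 2, which also carries methoxy but has a different aryl group on the urea, gives 4980 nM and so methoxy alone does not go with the higher number of compound 2.

As far as these compounds go, whether an ethoxy group, a longer chain on this oxygen, or an amine in its place would hold the same level remains open. Nothing available accounts for the two groups reading alike.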